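The source may hold more compounds than are shown below. What is called first, only, known or untested is meant among the compounds shown, and "the series" means these compounds.

- Compound 1 `O=C1CCCCC/C1=C\c1ccc(F)cc1` gives > 50000 nM as a limit of the assay, not a number
- Compound 2 `O=C1CCCCC/C1=C\c1ccc(Cl)cc1` gives 19100 nM as a measured number
- Compound 3 `O=C1CCCCC/C1=C\c1ccc(Br)cc1` gives 16800 nM as a measured number

All three were tested in a functional assay on P388 cells (Mus musculus) for inhibition (a higher number here means a weaker inhibitor, a lower number a stronger inhibitor), and differ only in the halogen. Compound 3 stands level with compound 2, since bromo in place of chloro gave a 1.1-fold lower number from compound 2 to compound 3 (0.06 log units; within the scatter) and nothing more. The steps away from fluoro are larger: chloro in place of fluoro gave an at least 2.6-fold lower number from compound 1 to compound 2 (0.41 log units; beyond the scatter) and bromo in place of fluoro gave an at least 2.9-fold lower number from compound 1 to compound 3 (0.47 log units; beyond the scatter) in the same test.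

Compound 4 `Cc1ccc(/C=C2\CCCCCC2=O)cc1` carries methyl in place of bromo on an aromatic carbon at the same place. Within the data shown here, no measured step involves methyl, so the halogen steps offer only loose guidance. Among the measured compounds shown here, the closest precedent is the swap between compound 2 and compound 3, with its a 1.1-fold lower number from compound 2 to compound 3 (0.06 log units; within the scatter) result, so no change beyond the scatter is expected. The expected step is a 1.3-fold higher number from compound 3 to compound 4 (0.12 log units; within the scatter) in this test. For compound 4 the estimated value is 22000 nM with an expected range from 9000 nM to 48000 nM when measured.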

Compound 4, half-maximal inhibitory concentration: > 50000 nM
Compound 4 was reported as a limit; the forecaster's own chance of this, stated with the estimate: 15%; middle value at least 2.2-fold (0.35 log units) away from the limit.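

Methyl in place of bromo gave an at least 2.9-fold higher number from compound 3 to compound 4 (0.47 log units; beyond the scatter), and methyl in place of chloro gave an at least 2.6-fold higher number from compound 2 to compound 4 (0.41 log units; beyond the scatter). Methyl and bromo each count one heavy atom on the aromatic carbon, so that count alone does not decide the outcome at this place, and among the groups shown only chloro and bromo give a measured number, with fluoro in compound 1 and methyl in compound 4 going against any idea that any small group will do. The step from compound 1 to compound 4 cannot be read, since both compounds stand at a limit and not at a number: the limit of > 50000 nM in this assay, at which 2 of the 4 values shown sit.

The compounds shown leave open whether an amine, a methoxy group or trifluoromethyl at this place would give a measured number. They also leave open whether any group can go beyond the level of compound 2 and compound 3.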